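The source may hold more compounds than are shown below. What is called first, only, known or untested is meant among the compounds shown, and "the series" means these compounds.

Of the compounds shown here, three sharing one core have been measured in a functional assay on MCF7 cells (Homo sapiens) for inhibition, read by MTT assay, with a stated time of 72 h; on this read-out lower numbers stand for stronger inhibition of growth and higher numbers for weaker inhibition of growth. Compound 1 `CCOC(=O)/C=C/C1=CC[C@H]2C(C)(C)CCC[C@]2(C)[C@H]1C=O` gives 30000 nM, compound 2 `CC(C)(C)OC(=O)/C=C/C1=CC[C@H]2C(C)(C)CCC[C@]2(C)[C@H]1C=O` gives 32000 nM, and compound 3 `COC(=O)/C=C/C=C/C1=CC[C@H]2C(C)(C)CCC[C@]2(C)[C@H]1C=O` gives 31000 nM. Compound 3 thus lies within the scatter of both others. Compound 4 `CC1(C)CCC[C@]2(C)[C@@H](C=O)C(/C=C/C#N)=CC[C@@H]12` differs from compound 3 in one place: cyano in place of 2-(methoxycarbonyl)ethenyl on a double-bonded chain carbon bound to a double-bonded chain carbon. This puts cyano in place of 2-(methoxycarbonyl)ethenyl on a double-bonded chain carbon bound to a double-bonded chain carbon. Two measured steps alter the group at this same place, a 1.0-fold higher number from compound 1 to compound 3 (0.01 log units; within the scatter) and a 1.0-fold lower number from compound 2 to compound 3 (0.01 log units; within the scatter). A third, a 1.1-fold higher number from compound 1 to compound 2 (0.03 log units; within the scatter), alters only the group on the oxygen next to the carbonyl group. All three steps stay within the scatter. Within the data shown here, no measured compound carries cyano, so that group itself remains untested. No step beyond the scatter is therefore expected in this assay, and no direction is favoured, though the uncertainty is wide. The expected step is a 1.0-fold lower number from compound 3 to compound 4 (0.01 log units; within the scatter). For compound 4 the estimated value is 30000 nM, with an expected range from 12000 nM to 70000 nM.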

Compound 4, concentration for 50% growth inhibition: 31000 nM
For compound 4 the middle estimate is 1.0-fold (0.01 log units) below the measured one, and the stated range covers the measured number.
By their numbers in this assay, from the lowest: compounds 1, 3, 4 and 2 (each within the scatter of the next).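

In this assay the exchange of 2-(methoxycarbonyl)ethenyl for cyano gives no change at the digits printed from compound 3 to compound 4 (within the scatter) and the comparisons with the other two compounds give a 1.0-fold lower number from compound 2 to compound 4 (0.01 log units; within the scatter) and a 1.0-fold higher number from compound 1 to compound 4 (0.01 log units; within the scatter), so all three new steps stay within the scatter. Until now every group at this place, on a double-bonded chain carbon bound to a double-bonded chain carbon, was ethoxycarbonyl, tert-butoxycarbonyl or 2-(methoxycarbonyl)ethenyl, each with oxygen atoms. Compound 4 shows that cyano, which has none and is the smallest of these groups, leaves the number in this assay where those groups had it.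

From the compounds shown here alone, it remains open whether a carboxylic acid or an amine at this place would move the number in this assay beyond the scatter. No measurement given here offers any explanation for these numbers.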